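The compounds below may be only part of what the source reports. "The series", "measured", "known", "first", "only" and "open" are said of these compounds alone.

Three compounds have been measured in an assay on L cells for inhibition of Protein-serine O-palmitoleoyltransferase porcupine (Mus musculus), read by reporter gene assay, with a stated time of 24 h; on this read-out higher numbers stand for an effect only at larger amounts of compound and lower numbers for an effect already at smaller amounts:
compound 1, `Cc1ccc2nc(NC(=O)CNC(=O)c3nn(-c4ccccc4)c(=O)c4ccccc34)sc2c1`, gives 35 nM
compound 2, `O=C(CNC(=O)c1nn(-c2ccccc2)c(=O)c2ccccc12)Nc1nc2ccc(C(F)(F)F)cc2s1`, gives 110 nM
compound 3, `O=C(CSc1nc2c(c(=O)n1-c1ccc(F)cc1)SCC2)Nc1nc2ccc(C(F)(F)F)cc2s1`, gives 100 nM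

Compound 1 and compound 2 share one core and differ in a single group; the step of a 3.1-fold lower number from compound 2 to compound 1 (0.50 log units; beyond the scatter) came with the change (methyl in place of trifluoromethyl on an aromatic carbon). Compound 3 carries a different core, and the difference between the two cores is not broken down here. Compound 4, `Cc1ccc2nc(NC(=O)CSc3nc4c(c(=O)n3-c3ccc(F)cc3)SCC4)sc2c1`, has not yet been measured in this assay; it stands to compound 3 as compound 1 stands to compound 2, through the same change at the same place, (methyl in place of trifluoromethyl on an aromatic carbon). Compound 4 is expected to follow with a step of similar size, a 2.5-fold lower number from compound 3 to compound 4 (0.40 log units; beyond the scatter), because the same change gave a 3.1-fold lower number from compound 2 to compound 1 (0.50 log units; beyond the scatter), though this rests on one example only. Compound 4 is therefore estimated at 40 nM, most likely between 15 nM and 100 nM.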

Compound 4, half-maximal effective concentration: 40 nM
For compound 4 middle estimate and measured number coincide at the digits printed; the measured number falls inside the stated range.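

On the core of compound 3, methyl in place of trifluoromethyl gave a 2.5-fold lower number from compound 3 to compound 4 (0.40 log units; beyond the scatter) and so moved the number in the same direction as on the core of compound 1. The two steps agree in size: the same change on two cores in this assay, a 3.1-fold lower number (0.50 log units; beyond the scatter) from compound 2 to compound 1 and a 2.5-fold lower number (0.40 log units; beyond the scatter) from compound 3 to compound 4, 1.3-fold (0.10 log units) apart, within the scatter of two such steps

In this series the change therefore carried over between these two cores, but two pairs cannot show that it would hold on a third core, and they do not explain why methyl gives the lower number.

The compounds shown leave open how other groups on this aromatic carbon would compare, such as a chlorine atom, a methoxy group or an amine. They also leave open what a plain hydrogen there would give on either core.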